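The compounds below may be only part of what the source reports. "The series", "measured", "known", "first", "only" and "open" are said of these compounds alone.

Among the measured compounds shown here, the three compounds measured so far share one core and differ only at the amide end. Compound 1 `COc1cc2c(cc1OC)C(CC(N)=O)CC2` carries the unsubstituted amide; compound 2 `CNC(=O)CC1CCc2cc(OC)c(OC)cc21` the methylamino amide; compound 3 `CCN(CC)C(=O)CC1CCc2cc(OC)c(OC)cc21` the diethylamino amide. In a functional assay on the whole organism (strain Wistar) for inhibition, with Rattus norvegicus as the target, read by paw edema, with stated times of 60 min and 1 h, at a dose of 100 mg/kg by the oral route (on this read-out higher numbers stand for more inhibition at the one dose given (going by the name of the read-out) and lower numbers for less inhibition), compound 1 gives 18.8%, compound 2 gives 15.6%, and compound 3 gives 31.3%, the highest of the three. The step of a number 3.2 percentage points lower from compound 1 to compound 2 (within the scatter) changes little, whereas a number 12.5 percentage points higher from compound 1 to compound 3 (beyond the scatter) and a number 15.7 percentage points higher from compound 2 to compound 3 (beyond the scatter) both rise beyond the scatter.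

Compound 4 `CCCNC(=O)CC1CCc2cc(OC)c(OC)cc21` is not yet measured. It differs from compound 3 by propylamino in place of diethylamino on a carbonyl carbon. The change moves back toward the secondary amides of compound 2 and compound 1, keeping one hydrogen-bond donor but with a longer chain than compound 2. The bearing steps are a number 15.7 percentage points higher from compound 2 to compound 3 (beyond the scatter) and a number 12.5 percentage points higher from compound 1 to compound 3 (beyond the scatter), so a partial reversal of those gains is expected, a number 8.3 percentage points lower from compound 3 to compound 4 (within the scatter), downward but modest. Compound 4 is therefore estimated at 23%, in the range 12% to 35%.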

Compound 4, a percentage reported as inhibition, in the whole organism at one dose (the size of the read-out at that dose, not a potency): 18.8%
For compound 4 the middle estimate is 4.2 percentage points above the measured one; low and high end bracket the measured number.
By their numbers in this assay, from the lowest: compounds 2, 1 and 4 (each within the scatter of the next); then compound 3.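

In this assay, the propylamino amide does not keep the level of the diethylamino amide, with a number 12.5 percentage points lower from compound 3 to compound 4 (beyond the scatter). It instead sits with the other two amides that keep an amide hydrogen, with a number 3.2 percentage points higher from compound 2 to compound 4 (within the scatter) and no change at the digits printed from compound 1 to compound 4 (within the scatter), so among these four compounds going from hydrogen through methyl to propyl on the amide nitrogen stays within the scatter, and only the diethylamino amide of compound 3, with no hydrogen-bond donor there, stands apart. No measurement shown bears on the reason for this difference.

The compounds shown leave open whether the higher number goes with the missing amide hydrogen or with the two ethyl groups as such, which a dimethylamino or piperidine amide could help to separate. They also leave open how a longer chain such as butyl on the amide nitrogen would read.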